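Thiazole acetic acids: swapping the aryl group on the core

A few compounds are considered here, and "the series" means these few. Any claim that something is new, unique, unknown or untested is made for them only; others in the source may bear on it.

Measured so far:
- compound 1, `Nc1nc(-c2ccc(Cl)cc2)c(CC(=O)O)s1`: > 100000 nM
- compound 2, `O=C(O)Cc1sc(C(c2ccc(F)cc2)c2ccc(F)cc2)nc1-c1ccnc(N2CCCC2)c1`: 230 nM
- compound 3, `O=C(O)Cc1sc(C(c2ccccc2)c2ccccc2)nc1-c1ccc(C(F)(F)F)cc1`: 1100 nM

The series is followed in an in vitro assay on HEK385-7 cells for displacement of a labelled ligand from prostaglandin D2 receptor 2 (Homo sapiens); on this read-out lower numbers stand for stronger inhibition and higher numbers for weaker inhibition. Compound 1 returns only a limit, > 100000 nM, so it gives no number for comparison. Among the two numbers available, compound 2 stands lowest with 230 nM; compound 3 gives 1100 nM, a gap that lies beyond the scatter. Going by the values given here, compound 2 and compound 3 differ in more than one place, so the two values show only that the pair with the pyrrolidinylpyridine and the bis(fluorophenyl)methyl group is the stronger of the two.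

The next compound, compound 4, `O=C(O)Cc1sc(C(c2ccc(F)cc2)c2ccc(F)cc2)nc1-c1ccc(Cl)cc1`, is not yet measured. It keeps the bis(fluorophenyl)methyl group of compound 2 and changes only the aryl group on the shared core:

4-chlorophenyl in place of 2-(pyrrolidin-1-yl)pyridin-4-yl on an aromatic carbon

The change removes both hydrogen-bond acceptors of the leaving group and shrinks it. Among the compounds with values here, no measured pair isolates this change, so the direction is read from what is at hand: compound 3, carrying a plain carbon-only aryl group at the same place, gives 1100 nM, a weaker number than compound 2. On that basis a moderate step toward weaker inhibition from compound 2 to compound 4 is expected, a 3.5-fold higher number from compound 2 to compound 4 (0.54 log units; beyond the scatter), and compound 4 is estimated at 800 nM, in the range 250 nM to 3000 nM.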

Compound 4, half-maximal inhibitory concentration: 9.7 nM
The estimate for compound 4 lay 82-fold (1.92 log units) above the measured number, outside the stated range (below it).
By their numbers in this assay, from the lowest: compound 4; then compound 2; then compound 3. At a limit, above all of these: compound 1.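

In this assay the aryl place on the shared core, next to the ring nitrogen, can now be read through a single change, and that change has a large effect: a 24-fold lower number from compound 2 to compound 4 (1.37 log units; beyond the scatter). With the bis(fluorophenyl)methyl group held fixed, the smaller 4-chlorophenyl, which has no hydrogen-bond acceptors, gives the lower number, so neither the pyrrolidine ring nor the pyridine nitrogen of the leaving group is needed for a low number at this place. Going by these compounds alone, compound 1 carries the same 4-chlorophenyl with an amine in place of the bis(fluorophenyl)methyl group, but its > 100000 nM is a limit and not a number, so no size can be given for a step from it, and it is the only such value in the set: the limit of > 100000 nM in this assay, at which 1 of the 4 values shown sits.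

Open, going by these compounds, is whether a plain phenyl or a 2-aminopyridin-4-yl at this place would sit nearer compound 4 or compound 2, which would separate the part played by the chlorine from that of the pyrrolidine and the ring nitrogen. Also open, on these data alone, is whether the step keeps its size with a shorter alkyl chain in place of the bis(fluorophenyl)methyl group.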